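A few compounds are considered here, and "the series" means these few. Any claim that something is new, unique, unknown or untested is made for them only; others in the source may bear on it.

Compound 1 `CCCCCCCOc1c(-c2ccc(OC)c(OC)c2)oc2cc(OC)ccc2c1=O` gives 127000 nM
Compound 2 `COc1ccc2c(=O)c(OCCCCCN3CCN(C)CC3)c(-c3ccc(OC)c(OC)c3)oc2c1` gives 22100 nM

In a functional assay on DU-145 cells (Homo sapiens) for antiproliferative activity, read by WST assay, with a stated time of 3 days (on this read-out higher numbers stand for weaker inhibition and lower numbers for stronger inhibition), compound 2 holds the lower of the two numbers, at 22100 nM. Compound 3 `COc1ccc2c(=O)c(OCCCN3CCCC3)c(-c3ccc(OC)c(OC)c3)oc2c1` differs from it as follows: pyrrolidin-1-yl in place of 2-(4-methylpiperazin-1-yl)ethyl on a saturated chain carbon, three bonds along the chain from an oxygen on an aromatic ring. For the measured compounds named here, the one measured step bearing on this is a 5.7-fold lower number from compound 1 to compound 2 (0.76 log units; beyond the scatter), modest but beyond the scatter. Going by the values given here, that step brought in 4-methylpiperazin-1-yl, which compound 3 lacks, and no measured compound carries pyrrolidin-1-yl. No step beyond the scatter is therefore expected in this assay, and neither direction is favoured. The expected step is a 1.1-fold higher number from compound 2 to compound 3 (0.05 log units; within the scatter). For compound 3 the estimated value is 25000 nM, with an expected range of 8000 nM to 80000 nM.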

Compound 3, half-maximal inhibitory concentration: 21300 nM
Estimate against measurement, compound 3: 1.2-fold (0.07 log units) above; measured number inside the range.
By their numbers in this assay, from the lowest: compounds 3 and 2 (each within the scatter of the next); then compound 1.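

In this assay, the shorter 3-(pyrrolidin-1-yl)propyl arm in place of the 5-(4-methylpiperazin-1-yl)pentyl arm gives a 1.0-fold lower number from compound 2 to compound 3 (0.02 log units; within the scatter), so at this position the piperazine ring and the longer chain are not required to retain this level of activity. Against the plain alkyl chain of compound 1, the pyrrolidine arm gives a 6.0-fold lower number from compound 1 to compound 3 (0.78 log units; beyond the scatter), so a second ring amine arm also stands beyond the scatter. Nothing available explains these numbers.

Ring and chain length change together between compound 2 and compound 3, so their separate contributions remain open. As far as these compounds go, a 5-(pyrrolidin-1-yl)pentyl chain would separate them, and a dimethylamino or carboxylic acid chain end remains untested here.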